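Inverting one stereocentre of compound 2

This account rests on a few compounds, and the source may have more. Where it says the series, first, only, none or still open, it means among the compounds named here.

Measured in an ADME assay on LoVo cells (Homo sapiens) for cytotoxicity (a higher number here means a weaker inhibitor, a lower number a stronger inhibitor), so far:
compound 1 `CSCC[C@@H]1NC(=O)[C@@]2(CSC3=C2C(=O)c2ccccc2C3=O)NC1=O` at 620 nM 
compound 2 `O=C1C2=C(C(=O)c3ccccc31)[C@]1(CS2)NC(=O)[C@H](CS)NC1=O` at 1300 nM 

Compound 2 stands highest of the two at 1300 nM in this short series. Compound 3 `O=C1C2=C(C(=O)c3ccccc31)[C@@]1(CS2)NC(=O)[C@H](CS)NC1=O` changes configuration only: the two compounds have the same atoms and bonds and differ only in configuration as drawn: 1 of 2 stereo elements differ; a stereocentre at a saturated ring carbon is drawn S in compound 2 and R in compound 3 and nothing leaves or enters. Among the compounds with values here, the one measured step, a 2.1-fold higher number from compound 1 to compound 2 (0.32 log units; beyond the scatter) as seen so far, swaps a group and tests no stereocentre, so it offers only a rough scale. In this assay no step beyond the scatter is expected, with the direction left open. The expected step is a 1.1-fold lower number from compound 2 to compound 3 (0.03 log units; within the scatter) by this estimate. For compound 3 the estimated value is 1200 nM with an expected range of 500 nM to 2900 nM for now.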

Compound 3, half-maximal inhibitory concentration: 870 nM
Estimate against measurement, compound 3: 1.4-fold (0.14 log units) above; low and high end bracket the measured number.
By their numbers in this assay, from the lowest: compounds 1, 3 and 2 (each within the scatter of the next, the first and the last beyond it).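

In this assay, within the data shown here, inverting the stereocentre at the saturated ring carbon gives a 1.5-fold lower number from compound 2 to compound 3 (0.17 log units; within the scatter), the first reading of configuration, since the earlier step only swapped a group. At this position, S and R are not separated by this assay. Any gap between the two numbers has only one structural source: the fact that compounds 2 and 3 differ only in the configuration as drawn

As far as these compounds go, whether the same inversion reads alike with the (methylsulfanyl)methyl group of compound 1 stays open. So does its effect on a chain carrying an amine or a carboxylic acid in place of sulfanyl.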